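A few compounds are considered here, and "the series" means these few. Any claim that something is new, unique, unknown or untested is made for them only; others in the source may bear on it.

In a functional assay on NCI-H460 cells (Homo sapiens) for inhibition, read by MTT assay, with a stated time of 24 h, tested at 0.1 ug/mL (a lower number here means less inhibition of growth, a higher number more inhibition of growth at the concentration tested), compound 3 (`CC(=O)SCCC(CCCCC(=O)Nc1ccccc1)SC(C)=O`) gives 15.4% as the reference point. Compound 1 (`CC(=O)SCCC(CCCCC(=O)O)SC(C)=O`) gives 9.96% and stays within the scatter of compound 3. Compound 2 (`O=C(CCCCC1CCSS1)Nc1ccc(Cl)cn1`) gives 3.93% and lies lower than compound 3, beyond the scatter. Compound 4 (`CC(=O)SCCC(CCCCC(=O)Nc1ccccc1Cl)SC(C)=O`) is compound 3 with one change (chloro in place of hydrogen on an aromatic carbon), chloro in place of hydrogen on an aromatic carbon, ortho to a large group. Among the compounds with values here, the only measured step is a number 5.4 percentage points higher from compound 1 to compound 3 (within the scatter) and it concerns a carbonyl carbon, so no measured step tests a change on the aromatic ring. No step beyond the scatter is therefore expected in this assay here. The estimated step is a number 1.6 percentage points higher from compound 3 to compound 4 (within the scatter) in size. Compound 4 is expected at 17% with an estimated range of 7% to 30% in this series.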

Compound 4, percent growth inhibition at one concentration: 16.6%
Estimate against measurement, compound 4: 0.4 percentage points above; the range from low to high includes it.
By their numbers in this assay, from the lowest: compounds 2, 1, 3 and 4 (each within the scatter of the next, the first and the last beyond it).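

In this assay, within the data shown here, the aromatic ring of the anilino amide is tested for the first time: chloro in place of hydrogen on an aromatic carbon, ortho to a large group, gives a step within the scatter (a number 1.2 percentage points higher from compound 3 to compound 4 (within the scatter)). The second new step also stays within the scatter (a number 6.6 percentage points higher from compound 1 to compound 4 (within the scatter)). No supporting measurement bears on these results.

From the compounds shown here alone, it remains open whether methoxy or an amine on this aromatic carbon would give a step beyond the scatter. Going by these compounds, it also remains open whether chloro on another carbon of the ring would match this result.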